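Changing the amide ring when both values are limits

The source may report more compounds than this note shows. Statements on the series, on what has been measured and on what is new or still open speak of the compounds shown alone.

Compound 1 `CCN(CC)S(=O)(=O)c1ccc(S(=O)(=O)N2CCC[C@@H](C(=O)N3CCOCC3)C2)cc1`: > 10000 nM
Compound 2 `CCN(CC)S(=O)(=O)c1ccc(S(=O)(=O)N2CCC[C@@H](C(=O)N3CCC(COC)CC3)C2)cc1`: > 10000 nM
Compound 3 `CCN(CC)S(=O)(=O)c1ccc(S(=O)(=O)N2CCC[C@@H](C(=O)N3CCS(=O)(=O)CC3)C2)cc1`: not yet measured

Compound 1 and compound 2 share the same core and differ only in the ring attached to the carbonyl carbon. In a functional assay on MIA PaCa-2 cells (Homo sapiens) for inhibition, read by MTT assay, with a stated time of 3 days (on this read-out higher numbers stand for weaker inhibition and lower numbers for stronger inhibition), compound 1 gives > 10000 nM, which is a limit of the assay and not a number. In this assay compound 2 gives > 10000 nM, again a limit rather than a number. The step that the two limits leave unreadable from compound 1 to compound 2 therefore cannot be read in size or direction; both measured values sit at the limit of > 10000 nM in this assay, at which 2 of the 2 values shown sit. Compound 3 carries the change (1,1-dioxothiomorpholin-4-yl in place of 4-(methoxymethyl)piperidin-1-yl on a carbonyl carbon). Among the measured compounds shown here, the one measured step is unreadable, so it offers no basis for expecting a shift beyond the scatter in either direction. Because the limit of > 10000 nM in this assay, at which 2 of the 2 values shown sit, holds both measured compounds, compound 3 is expected to remain at that limit, with an estimated step that the limit leaves unreadable from compound 2 to compound 3. Compound 3 is estimated at 15000 nM, between 5000 nM and 50000 nM.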

Compound 3, half-maximal inhibitory concentration: > 10000 nM
Compound 3 ended at the assay's limit (the forecaster's own chance of this, stated with the estimate: 85%); the middle value is on the limit's open side.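

Compound 1, compound 2 and compound 3 all end at a limit of the assay and not at a number, so no step among them can be read in size or direction: the limit of > 10000 nM in this assay, at which 3 of the 3 values shown sit.

The compounds shown leave open which ring on the carbonyl carbon, if any, would give a measurable value in this assay.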